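The compounds below may be only part of what the source reports. "The series", "measured", "known", "first", "only" and "open" are said of these compounds alone.

Compound 1, `COc1cc2c(Oc3ccc(NC(=O)c4nn(-c5ccccc5C(F)(F)F)c(=O)cc4C)cc3F)ccnc2cc1OCCCN1CCCCC1`, is the starting point. In a functional assay on U-87MG ATCC cells (Homo sapiens) for inhibition, read by MTT assay, with a stated time of 72 h (on this read-out higher numbers stand for weaker inhibition and lower numbers for stronger inhibition), compound 1 gives 1150 nM. Compound 2, `COc1cc2c(Oc3ccc(NC(=O)c4nn(-c5ccccc5C(F)(F)F)c(=O)cc4C)cc3F)ccnc2cc1OCCCN1CCC(C)CC1`, carries one change, (methyl in place of hydrogen on a saturated ring carbon), and the step of a 1.0-fold lower number from compound 1 to compound 2 (0.01 log units; within the scatter) is about as small as a step can be. In this assay compound 2 gives 1120 nM. Compound 3, `COc1cc2c(Oc3ccc(NC(=O)c4nn(-c5ccccc5OC(F)(F)F)c(=O)cc4C)cc3F)ccnc2cc1OCCCN1CCCCC1`, changes the shared core of compound 1 in a different way, (trifluoromethoxy in place of trifluoromethyl on an aromatic carbon), and the step of a 1.1-fold higher number from compound 1 to compound 3 (0.05 log units; within the scatter) again stays small; in this assay compound 3 gives 1300 nM. Compound 4, `COc1cc2c(Oc3ccc(NC(=O)c4nn(-c5ccccc5OC(F)(F)F)c(=O)cc4C)cc3F)ccnc2cc1OCCCN1CCC(C)CC1`, has not yet been measured. It differs from compound 3 by methyl in place of hydrogen on a saturated ring carbon, the same change that turns compound 1 into compound 2. Because the earlier step of a 1.0-fold lower number from compound 1 to compound 2 (0.01 log units; within the scatter) was so small, the step from compound 3 to compound 4 is expected to be about as small, no change at the digits printed from compound 3 to compound 4 (within the scatter). Compound 4 is therefore estimated at 1300 nM, most likely between 650 nM and 2600 nM.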

Compound 4, half-maximal inhibitory concentration: 800 nM
Beside the measured number, compound 4's estimate is 1.6-fold (0.21 log units) above it; low and high end bracket the measured number.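

In this assay, the methyl that turns piperidin-1-yl into 4-methylpiperidin-1-yl gives a 1.6-fold lower number from compound 3 to compound 4 (0.21 log units; within the scatter), and this step agrees with the earlier one on the other core: the same change on two cores in this assay, a 1.0-fold lower number (0.01 log units; within the scatter) from compound 1 to compound 2 and a 1.6-fold lower number (0.21 log units; within the scatter) from compound 3 to compound 4, 1.6-fold (0.20 log units) apart, within the scatter of two such steps. Putting trifluoromethoxy in place of trifluoromethyl gives a 1.4-fold lower number from compound 2 to compound 4 (0.15 log units; within the scatter), which likewise agrees with its earlier counterpart: the same change on two cores in this assay, a 1.1-fold higher number (0.05 log units; within the scatter) from compound 1 to compound 3 and a 1.4-fold lower number (0.15 log units; within the scatter) from compound 2 to compound 4, 1.6-fold (0.20 log units) apart, within the scatter of two such steps. Each change therefore carries from one core to the other with no difference that stands out from the scatter, but all these steps are small, so this does not show that either change has a real effect, nor that the agreement would hold on further cores.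

The compounds shown leave open what an ethyl group or a carboxylic acid would do in place of the methyl. They also leave open what a morpholine would do in place of the piperidine ring.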